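The compounds below may be only part of what the source reports. "The series", "measured", "known", "first", "only" and "open" are said of these compounds alone.

Measured compounds in a functional assay on MCF7 cells (Homo sapiens) for inhibition, read by XTT assay, with a stated time of 48 h; a lower number here means a stronger inhibitor, a higher number a weaker inhibitor:

Compound 1 `COc1ccc(C(=O)/C(=C/c2ccccc2F)CCOC(C)=O)cc1` — compound 1 gives > 100000 nM, a limit of the assay.
Compound 2 `COc1ccc(C(=O)/C(=C/c2ccc([N+](=O)[O-])cc2)CCOC(C)=O)cc1` — compound 2 gives > 100000 nM, a limit of the assay.
Compound 3 `COc1ccc(C(=O)/C(=C/c2ccc(Cl)cc2)CCOC(C)=O)cc1` — compound 3 gives > 100000 nM, a limit of the assay.

For the measured compounds named here, compound 3 therefore stands at the limit, and the limit of > 100000 nM in this assay, at which 3 of the 3 values shown sit, shows that no measured compound gives a readable number. The steps to compound 3, a step that the two limits leave unreadable from compound 1 to compound 3 and a step that the two limits leave unreadable from compound 2 to compound 3, are unreadable for the same reason, as is a step that the two limits leave unreadable from compound 1 to compound 2. Compound 4 `COc1ccc(C(=O)/C(=C/c2ccc(Cl)cc2)CC(C)OC(C)=O)cc1` differs from compound 3 by methyl in place of hydrogen on a saturated chain carbon bound to an oxygen next to a carbonyl group and a saturated chain carbon. Going by the values given here, no measured step bears on such a change, so no direction can be expected, and for compound 4 the estimate is 150000 nM, with a range from 50000 nM to 500000 nM. The expected step from compound 3 is a step that the limit leaves unreadable from compound 3 to compound 4, most likely again ending at the limit.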

Compound 4, half-maximal inhibitory concentration: > 100000 nM
Compound 4: a limit, no number (the forecaster's own chance of this, stated with the estimate: 85%); the middle value lies beyond the limit too.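

In this assay compound 4 gives > 100000 nM, also a limit, so no step from compound 3 to compound 4 can be read: the limit of > 100000 nM in this assay, at which 4 of the 4 values shown sit.

The compounds shown leave open whether any change to the shared core would give a readable number.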